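Amide-nitrogen variation at the cytotoxicity limit

A few compounds are considered here, and "the series" means these few. Any claim that something is new, unique, unknown or untested is made for them only; others in the source may bear on it.

Compound 3 `COCOc1cc(/C=C/C(=O)OCC(=O)Nc2nccs2)ccc1OCc1ccccc1` carries a 1,3-thiazol-2-yl group on the amide-type nitrogen of the shared core. In a functional assay on PC-3 cells (Homo sapiens) for cytotoxicity, read by MTT assay, with a stated time of 72 h (on this read-out lower numbers stand for stronger inhibition and higher numbers for weaker inhibition), compound 3 gives > 200000 nM, which is a limit of the assay and not a number. The two other members stand at the same place. Compound 1 `COCOc1cc(/C=C/C(=O)OCC(=O)Nc2ccc(OC)cc2)ccc1OCc1ccccc1` gives > 200000 nM in this assay, a limit. Compound 2 `COCOc1cc(/C=C/C(=O)OCC(=O)NN2CCOCC2)ccc1OCc1ccccc1` gives > 200000 nM in this assay, again a limit. The steps a step that the two limits leave unreadable from compound 1 to compound 2, a step that the two limits leave unreadable from compound 1 to compound 3 and a step that the two limits leave unreadable from compound 2 to compound 3 therefore cannot be sized in either direction; the only thing the series shows is the limit of > 200000 nM in this assay, at which 3 of the 3 values shown sit.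

Compound 4 `COCOc1cc(/C=C/C(=O)OCC(=O)NCc2ccco2)ccc1OCc1ccccc1` differs from compound 3 by (furan-2-yl)methyl in place of 1,3-thiazol-2-yl on an amide-type nitrogen. Going by the values given here, none of the measured steps can be read as bearing on this change, because the limit of > 200000 nM in this assay, at which 3 of the 3 values shown sit, is all that the three values give. The step from compound 3 to compound 4 is expected to be unreadable as well, a step that the limit leaves unreadable from compound 3 to compound 4, with no direction beyond the scatter. Compound 4 is therefore estimated in this assay at 250000 nM, with an expected range from 80000 nM to 1000000 nM, most likely reported only as a limit.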

Compound 4, half-maximal inhibitory concentration: > 200000 nM
Compound 4: a limit, no number; the forecaster's own chance of this, stated with the estimate: 85%; the middle value lies beyond the limit too.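

No new step can be read for compound 4 against compound 1, compound 2 or compound 3, since all of them end at the same limit in this assay: the limit of > 200000 nM in this assay, at which 4 of the 4 values shown sit.

The compounds shown leave open whether any group on the amide-type nitrogen of the shared core gives a measurable value in this assay, and so how these groups would rank.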